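The source may hold more compounds than are shown below. What is called first, only, known or untested is meant among the compounds shown, and "the series" means these compounds.

Measured compounds:
compound 1, `CC(=O)Nc1cccc(C2CCN(CCCn3c(-c4ccccc4C(F)(F)F)nc4ccccc43)CC2)c1`, 50 nM
compound 2, `COc1ccccc1-c1nc2ccccc2n1CCCN1CCC(c2cccc(NC(C)=O)c2)CC1`, 747 nM
compound 3, `CC(=O)Nc1cccc(C2CCN(CCCn3c(-c4ccc(Cl)cc4Cl)nc4ccccc43)CC2)c1`, 3 nM

These three compounds were tested in an assay for displacement of a labelled ligand from melanin-concentrating hormone receptor 1 (Homo sapiens), read by fluorescence; on this read-out lower numbers stand for stronger inhibition and higher numbers for weaker inhibition. Compound 2 stands at the weak end of this small set: compound 1 gives 50 nM, while compound 2 gives 747 nM, a gap recorded as a 15-fold higher number from compound 1 to compound 2 (1.17 log units; beyond the scatter), and the step to compound 3 is large, a 250-fold lower number from compound 2 to compound 3 (2.40 log units; beyond the scatter). Compound 4, `CC(=O)Nc1cccc(C2CCN(CCCn3c(-c4ccc(F)c(F)c4)nc4ccccc43)CC2)c1`, is not yet measured. It differs from compound 2 in one place: 3,4-difluorophenyl in place of 2-methoxyphenyl on an aromatic carbon.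

Among the measured compounds shown here, two measured steps bear on this change, both at the same place of the shared core. The measured step of a 15-fold higher number from compound 1 to compound 2 (1.17 log units; beyond the scatter), read in reverse, shows that replacing the methoxy group with trifluoromethyl lowers the number by a wide margin, and moving to 2,4-dichlorophenyl gave a 250-fold lower number from compound 2 to compound 3 (2.40 log units; beyond the scatter). Both steps away from 2-methoxyphenyl lowered the number far beyond the scatter. From the compounds shown here alone, the 3,4-difluorophenyl group has not been tested, so its exact standing is unknown, but a large decrease is expected, roughly a 19-fold lower number from compound 2 to compound 4 (1.27 log units; beyond the scatter). Compound 4 is therefore estimated at 40 nM, within 8 nM to 200 nM.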

Compound 4, half-maximal inhibitory concentration: 4 nM
For compound 4 the middle estimate is 10-fold (1.00 log units) above the measured one, and the stated range ends above it.
By their numbers in this assay, from the lowest: compounds 3 and 4 (each within the scatter of the next); then compound 1; then compound 2.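

The 2-methoxyphenyl group of compound 2 now looks like the outlier among the groups tested at this position, since 3,4-difluorophenyl also gives a far lower number (a 190-fold lower number from compound 2 to compound 4 (2.27 log units; beyond the scatter)). Low numbers here do not depend on chlorine, as 3,4-difluorophenyl and 2,4-dichlorophenyl stay level (a 1.3-fold higher number from compound 3 to compound 4 (0.12 log units; within the scatter)). Nor is any group free of methoxy enough to reach this level, since 3,4-difluorophenyl also clearly improves on 2-(trifluoromethyl)phenyl (a 13-fold lower number from compound 1 to compound 4 (1.10 log units; beyond the scatter)).

No measurement here explains why these groups differ. From the compounds shown here alone, whether an unsubstituted phenyl, a pyridine ring or a cyclohexyl group would hold the low numbers at this position remains open.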